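Lengthening the Sulfur-Bound Chain of Compound 2

The source may hold more compounds than are shown below. What is called first, only, known or untested is meant among the compounds shown, and "the series" means these compounds.

Going by the values given here, compound 2 `CCCCCCSC[C@H](NC(C)=O)C(=O)CCl` is the stronger of the two compounds measured so far: in a functional assay on NALM-6 cells (Homo sapiens) (a lower number here means a stronger inhibitor, a higher number a weaker inhibitor), compound 2 gives 3300 nM, whereas compound 1 `CCCSC[C@H](NC(C)=O)C(=O)CCl` gives 6900 nM. The gap between them is the step of a 2.1-fold lower number from compound 1 to compound 2 (0.32 log units; beyond the scatter).

Compound 3 `CCCCCCCCCSC[C@H](NC(C)=O)C(=O)CCl` is not yet measured. It differs from compound 2 by propyl in place of hydrogen on a saturated chain carbon, six bonds along the chain from a sulfur. Among the compounds with values here, the only measured step that bears on this is a 2.1-fold lower number from compound 1 to compound 2 (0.32 log units; beyond the scatter), where the same kind of addition, placed three bonds along the chain from a sulfur rather than six, brought a modest gain. On that single precedent, a further modest drop in this assay is expected for compound 3, though one earlier step is a thin basis. For compound 3 the expected step is a 1.7-fold lower number from compound 2 to compound 3 (0.24 log units; within the scatter). Compound 3 is therefore estimated at 1900 nM in this assay, with a range from 700 nM to 5000 nM.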

Compound 3, half-maximal inhibitory concentration: 7300 nM
For compound 3 the middle estimate is 3.8-fold (0.58 log units) below the measured one; measured number above the stated range.
By their numbers in this assay, from the lowest: compound 2; then compounds 1 and 3 (each within the scatter of the next).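

In this assay the gain from lengthening the sulfur-bound chain does not continue: the same propyl addition, now six bonds along the chain from a sulfur, reverses the earlier improvement, giving a 2.2-fold higher number from compound 2 to compound 3 (0.34 log units; beyond the scatter) and not a further drop. With a 1.1-fold higher number from compound 1 to compound 3 (0.02 log units; within the scatter) the full hexyl addition leaves no gain at all, so compound 2 is the strongest of the three, and the number falls and then rises as the chain grows instead of moving in one direction. Nothing in the available data explains this turn.

Where the best length lies is still open, since a heptyl chain could fall on either side of the turn. Also open, on these data alone, is how a chain ending in an amine or a carboxylic acid would behave at this position.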